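The source may report more compounds than this note shows. Statements on the series, on what has been measured and on what is new or still open speak of the compounds shown alone.

Two hydroxamic acids built on a shared core open the series: compound 1 `O=C(/C=C/c1ccc(OCc2nc(C3CCN(Cc4ccccc4)CC3)no2)cc1)NO` and compound 2 `Cc1ccc(CN2CCC(c3noc(COc4ccc(/C=C/C(=O)NO)cc4)n3)CC2)cc1`. In an assay on isolated protein for inhibition of protein deacetylase HDAC6 (Homo sapiens), read by fluorescence, with a stated time of 1 h, tested at 100 nM (on this read-out lower numbers stand for less inhibition and higher numbers for more inhibition at the one concentration tested (going by the name of the read-out)), compound 1 gives 71%. In this assay compound 2 gives 76%. For the measured compounds named here, the one change between them is methyl in place of hydrogen on an aromatic carbon, and the step it made is a number 5 percentage points higher from compound 1 to compound 2 (within the scatter), so these two values cannot be told apart by this measurement.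

A third compound places the hydroxamic acid on a different core: compound 3 `CN(Cc1nc(C2CCN(Cc3ccccc3)CC2)no1)c1ncc(C(=O)NO)cn1`. In this assay compound 3 gives 63%. The difference between its core and the core of compound 1 is not broken down here. Its value sits within the scatter of compound 1, while the value of compound 2 lies beyond the scatter above it.

Compound 4 `Cc1cccc(CN2CCC(c3noc(CN(C)c4ncc(C(=O)NO)cn4)n3)CC2)c1` is not yet measured. It differs from compound 3 by methyl in place of hydrogen on an aromatic carbon. This is the same kind of change as that from compound 1 to compound 2, but not the same: there the methyl entered para to a large group, here it enters meta to a large group. Resting on the step seen from compound 1 to compound 2 being within the scatter, the step of a number 4 percentage points higher from compound 3 to compound 4 (within the scatter) is expected to be small as well. Compound 4 is therefore estimated at 67%, with the likely range running from 55% to 79%.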

Compound 4, a percentage reported as inhibition, at one concentration (the size of the read-out at that concentration, not a potency): 54%
Estimate against measurement, compound 4: 13 percentage points above; the measured number lies below the stated range.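

Adding a methyl to the benzyl group of compound 3 gave, in this assay, a number 9 percentage points lower from compound 3 to compound 4 (within the scatter), so compound 3 and compound 4 cannot be told apart by this measurement. Set beside the step on the other core, this step does not differ from it by more than the measurement can resolve: the same change on two cores in this assay, a number 5 percentage points higher (within the scatter) from compound 1 to compound 2 and a number 9 percentage points lower (within the scatter) from compound 3 to compound 4, 14 percentage points apart, within the scatter of two such steps. For the compounds shown here, this shows no sign that the core alters what the methyl does, but it does not show that the change carries over unaltered: each step is small against the scatter, only two pairs are available, and the methyl does not stand in the same place on the ring in compound 2 as in compound 4.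

The compounds shown leave open what the methyl would do at one and the same place on the ring on both cores, and whether a single reading at one concentration would hide a difference that a full potency measurement could reveal. They also leave open whether a larger change to the benzyl group, such as a methoxy group, a chlorine, an amine or a carboxylic acid on the ring, or a longer chain in place of benzyl, would give steps beyond the scatter on either core.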